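This account rests on a few compounds, and the source may have more. Where it says the series, first, only, none or still open, it means among the compounds named here.

Within the data shown here, compound 1 `O=C(NCCCCc1ccccc1)n1c(=O)oc2ccccc21` gives 64 nM in an assay on HEK293 cells for inhibition of acid ceramidase (Homo sapiens), with a stated time of 10 min (on this read-out lower numbers stand for stronger inhibition and higher numbers for weaker inhibition), the highest of the three numbers measured so far. Compound 2 `O=C(NCCCCc1ccccc1)n1c(=O)oc2cc(Cl)ccc21` gives 33 nM in this assay, and compound 3 `O=C(NCCCCc1ccccc1)n1c(=O)oc2ccc(Br)cc21` gives 22 nM in this assay. The step from compound 1 to compound 4 `Cc1cccc2c1oc(=O)n2C(=O)NCCCCc1ccccc1` is methyl in place of hydrogen on an aromatic carbon, the new group sitting ortho to a fused ring and meta to a fused ring. The measured steps that bear on it are both substitutions of an aromatic hydrogen on the core, though with halogens rather than methyl: a 1.9-fold lower number from compound 1 to compound 2 (0.29 log units; within the scatter) and a 2.9-fold lower number from compound 1 to compound 3 (0.46 log units; beyond the scatter). Among the measured compounds shown here, a methyl at this place has no direct precedent, so for compound 4 a small move to a lower number in this assay, or none beyond the scatter, is expected. The estimate for compound 4 in this assay is 50 nM, with a range of 20 nM to 125 nM, corresponding to an expected step of a 1.3-fold lower number from compound 1 to compound 4 (0.11 log units; within the scatter).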

Compound 4, half-maximal inhibitory concentration: 23 nM
Beside the measured number, compound 4's estimate is 2.2-fold (0.34 log units) above it, and the stated range covers the measured number.
By their numbers in this assay, from the lowest: compounds 3, 4, 2 and 1 (each within the scatter of the next, the first and the last beyond it).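

In this assay, methyl on this aromatic carbon, ortho to a fused ring and meta to a fused ring, gives a 2.8-fold lower number from compound 1 to compound 4 (0.44 log units; beyond the scatter), so a step beyond the scatter on the shared core is not confined to a halogen. It is the second such step in the series, alongside a 2.9-fold lower number from compound 1 to compound 3 (0.46 log units; beyond the scatter), while the chloro step a 1.9-fold lower number from compound 1 to compound 2 (0.29 log units; within the scatter) stays within the scatter. No available evidence explains the methyl step.

Going by these compounds, whether ethyl, methoxy or an amine at this carbon would give a similar number remains open. Also open, on these data alone, is whether methyl on the other aromatic carbons of the core would match this step.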